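The compounds below may be only part of what the source reports. "The series", "measured", "known", "first", "only" and "open" are said of these compounds alone.

Series values in an ADME assay on microsomes from liver (Homo sapiens) for metabolic stability, read by LC-MS, with a stated time of 30 min, tested at 1 uM; on this read-out higher numbers stand for a more stable compound and lower numbers for a less stable compound:
- compound 1 `O=C(NCc1ccc(S(=O)(=O)c2ccccc2)cc1)c1cc2ccncc2s1`: 48%
- compound 2 `O=C(NCc1ccc(S(=O)(=O)c2ccccc2)cc1)c1ccc2nncn2c1`: 96%
- compound 3 `O=C(NCc1ccc(S(=O)(=O)c2cc(F)cc(F)c2)cc1)c1cnc2nccn2c1`: 78%

Not yet measured: compound 4 `O=C(NCc1ccc(S(=O)(=O)c2ccccc2)cc1)c1cnc2nccn2c1`.

Compound 3 stands second of the three, with 78%, under compound 2 at 96%. Compound 1 stands last at 48%. The next change is phenyl in place of 3,5-difluorophenyl on a sulfonyl sulfur. For the measured compounds named here, only one measured step exists, a number 48 percentage points higher from compound 1 to compound 2 (beyond the scatter). It is large, but it lies on a carbonyl carbon, and both of its compounds carry phenyl on the sulfonyl sulfur. It therefore shows how much the group on the carbonyl carbon can matter, and says nothing directly about the group now changing. Going by the values given here, no measured pair isolates the sulfonyl substituent, so compound 3 at 78% is the only anchor. The expected step is small, a number 4 percentage points lower from compound 3 to compound 4 (within the scatter), and is not expected to exceed the scatter. For compound 4 the estimated value is 74%, with an expected range of 58% to 90%.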

Compound 4, percent of the compound remaining: 60%
For compound 4 the middle estimate is 14 percentage points above the measured one, and the stated range covers the measured number.
By their numbers in this assay, from the lowest: compound 1; then compound 4; then compound 3; then compound 2.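

In this assay the sulfonyl substituent now has an isolated reading, with phenyl in place of 3,5-difluorophenyl giving a number 18 percentage points lower from compound 3 to compound 4 (beyond the scatter) on a shared core. With phenyl held on the sulfonyl sulfur, the group on the carbonyl carbon gives a number 36 percentage points lower from compound 2 to compound 4 (beyond the scatter) and a number 12 percentage points higher from compound 1 to compound 4 (beyond the scatter) and so the three groups there now stand in order, that of compound 2 highest and that of compound 1 lowest. Nothing on hand gives a reason for the step on the sulfonyl sulfur.

For the compounds shown here, only one pair carries this change, and whether 3,5-difluorophenyl gives a step of like size with the carbonyl-side groups of compound 1 or compound 2 stays open. Also open, from the compounds shown here alone, is how 3-fluorophenyl, or a methoxy or chlorine on the same ring, would read against these values.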